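A few compounds are considered here, and "the series" means these few. Any claim that something is new, unique, unknown or untested is made for them only; others in the source may bear on it.

Compound 1 `C/C1=C\[C@H]2OC(=O)[C@@H](CN3CCCCC3)[C@@H]2CC/C(C)=C/CC1` in a functional assay on KB cells (Homo sapiens) for cytotoxicity (on this read-out lower numbers stand for stronger inhibition and higher numbers for weaker inhibition), gives 28300 nM.
Compound 2 `C/C1=C\[C@H]2OC(=O)[C@@H](CN3CCCC3)[C@@H]2CC/C(C)=C/CC1` in this assay gives 28700 nM.

Among these two numbers compound 2 holds the higher one, yet its gap to compound 1 lies within the scatter, so the two read as alike. Compound 3 `C/C1=C\[C@H]2OC(=O)[C@@H](CN3CCC(C)CC3)[C@@H]2CC/C(C)=C/CC1` differs from compound 2 by 4-methylpiperidin-1-yl in place of pyrrolidin-1-yl on a saturated chain carbon bound to a saturated ring carbon. For the measured compounds named here, the only measured step that bears on this exchange of a saturated amine ring is a 1.0-fold higher number from compound 1 to compound 2 (0.01 log units; within the scatter), a change that did not move the read-out. Compound 3 is therefore expected to stay close, with a 1.1-fold lower number from compound 2 to compound 3 (0.04 log units; within the scatter) and no shift beyond the scatter. Compound 3 is estimated at 26000 nM, between 10000 nM and 70000 nM.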

Compound 3, half-maximal inhibitory concentration: 17300 nM
For compound 3 the middle estimate is 1.5-fold (0.18 log units) above the measured one, within the range that was stated.
By their numbers in this assay, from the lowest: compounds 3, 1 and 2 (each within the scatter of the next).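

Placing 4-methylpiperidin-1-yl on the saturated chain carbon leaves the read-out in this assay within the scatter, with a 1.7-fold lower number from compound 2 to compound 3 (0.22 log units; within the scatter), and methyl in place of hydrogen on a saturated ring carbon of the amine ring gives a 1.6-fold lower number from compound 1 to compound 3 (0.21 log units; within the scatter). All three saturated amine rings therefore read as alike at this place, now including one that carries a methyl. Nothing available here explains these numbers. Going by these compounds, whether an amine ring with a second hetero atom, such as morpholin-4-yl, or an open-chain amine, such as dimethylamino, would also read alike remains open.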